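A few compounds are considered here, and "the series" means these few. Any claim that something is new, unique, unknown or untested is made for them only; others in the source may bear on it.

In an in vitro ADME assay on microsomes from liver (Mus musculus) for pharmacokinetics, read by LC-MS, with a stated time of 10 min, tested at 1 uM (a higher number here means faster removal of the compound, a lower number slower removal), compound 2 `Cc1ccc(NC(=O)[C@H]2CN(C)C[C@@H]2c2ccc(/C=C/C(=O)Nc3ccccc3N)cc2)cn1` gives 57 mL/min/kg and compound 1 `CN1C[C@H](C(=O)Nc2ccc(C3CC3)cc2)[C@@H](c2ccc(/C=C/C(=O)Nc3ccccc3N)cc2)C1` gives 60 mL/min/kg, two values within the scatter of each other. The change to compound 3 `CN1C[C@H](C(=O)NC2CC2)[C@@H](c2ccc(/C=C/C(=O)Nc3ccccc3N)cc2)C1` is cyclopropyl in place of 6-methylpyridin-3-yl on an amide-type nitrogen. Among the compounds with values here, the one measured step at this place, a 1.1-fold lower number from compound 1 to compound 2 (0.02 log units; within the scatter), lies within the scatter. Within the data shown here, no measured compound yet carries cyclopropyl there, so this single step is the only guide and it gives no direction. The expected change is a 1.1-fold lower number from compound 2 to compound 3 (0.04 log units; within the scatter), with nothing expected beyond the scatter. Compound 3 is estimated at 52 mL/min/kg, within an expected range of 28 mL/min/kg to 90 mL/min/kg.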

Compound 3, clearance: 7 mL/min/kg
Compound 3: middle estimate off by 7.4-fold (0.87 log units), on the high side, and the stated range ends above it.
By their numbers in this assay, from the lowest: compound 3; then compounds 2 and 1 (each within the scatter of the next).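

Cyclopropyl on the amide-type nitrogen gives an 8.1-fold lower number from compound 2 to compound 3 (0.91 log units; beyond the scatter) in this assay and an 8.6-fold lower number from compound 1 to compound 3 (0.93 log units; beyond the scatter) as well. This position therefore does affect the clearance, which the earlier pair, with 6-methylpyridin-3-yl and 4-cyclopropylphenyl within the scatter of each other, did not show. Nothing available explains the size of this step.
Still open, from the compounds shown here alone, is whether the low number is particular to cyclopropyl or would also hold for cyclobutyl, isopropyl or a longer alkyl chain at the same nitrogen. Going by these compounds, how a plain phenyl there would compare also remains unknown.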